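The compounds below may be only part of what the source reports. "The series", "measured", "known", "first", "only" and "open" are said of these compounds alone.

Compound 1 `COc1cc2nc(Cl)nc(NS(=O)(=O)c3ccccc3)c2cc1OC`: 6.06 ug/mL
Compound 2 `COc1cc2nc(N3CCCC3)nc(NS(=O)(=O)C3CC3)c2cc1OC`: 6.43 ug/mL
Compound 3 `COc1cc2nc(N3CCCC3)nc(NS(=O)(=O)c3ccc(C)cc3)c2cc1OC`: 8.61 ug/mL

In a functional assay on U-937 cells (Homo sapiens) for cytotoxicity, read by MTT assay, with a stated time of 24 h (a higher number here means a weaker inhibitor, a lower number a stronger inhibitor), compound 1 gives the lowest of the three numbers, yet neither compound 2 nor compound 3 is separated from it beyond the scatter. Compound 4 `COc1cc2nc(Cl)nc(NS(=O)(=O)Cc3ccccc3)c2cc1OC` has not yet been measured in this assay. It differs from compound 1 in one place: benzyl in place of phenyl on a sulfonyl sulfur.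

Among the compounds with values here, the only measured step that also alters the group on the sulfonyl sulfur is the one from compound 2 to compound 3, which gave a 1.3-fold higher number from compound 2 to compound 3 (0.13 log units; within the scatter). On that evidence, a change of the group on the sulfonyl sulfur is expected to move the number little, so compound 4 is expected to show a 1.1-fold higher number from compound 1 to compound 4 (0.03 log units; within the scatter), a step within the scatter. Compound 4 is therefore estimated at 6.5 ug/mL, with a range from 3.2 ug/mL to 13 ug/mL.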

Compound 4, half-maximal inhibitory concentration: 91.7 ug/mL
Estimate against measurement, compound 4: 14-fold (1.15 log units) below; the whole stated range lies below it.
By their numbers in this assay, from the lowest: compounds 1, 2 and 3 (each within the scatter of the next); then compound 4.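

In this assay, the group on a sulfonyl sulfur proves able to move the number strongly: benzyl in place of phenyl gives a large step (a 15-fold higher number from compound 1 to compound 4 (1.18 log units; beyond the scatter)), while the earlier change at this place stayed within the scatter (a 1.3-fold higher number from compound 2 to compound 3 (0.13 log units; within the scatter)). The two groups share one six-membered aromatic ring of carbon only, and benzyl has just one more carbon, so a small change here can carry a large step. Nothing measured here accounts for this step.

On these data alone, whether a longer chain, such as 2-phenylethyl, on the sulfonyl sulfur would raise the number further remains open. So does whether benzyl would give a similar step on the core of compound 2.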